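Phenol methylation carried onto a second core

This account rests on a few compounds, and the source may have more. Where it says the series, first, only, none or still open, it means among the compounds named here.

Compound 1 `O=C(/C=C\Nc1ccc(O)cc1)c1cn(-c2ccccc2)nc1-c1ccc(Cl)cc1` is the reference compound. In a functional assay on A549 cells (Homo sapiens) for antiproliferative activity, read by MTT assay, with a stated time of 48 h (on this read-out lower numbers stand for stronger inhibition and higher numbers for weaker inhibition), compound 1 gives 1910 nM. Compound 2 `COc1ccc(N/C=C\C(=O)c2cn(-c3ccccc3)nc2-c2ccc(Cl)cc2)cc1` carries the change (methyl in place of hydrogen on an oxygen on an aromatic ring), and in this assay compound 2 gives 6460 nM, a step of a 3.4-fold higher number from compound 1 to compound 2 (0.53 log units; beyond the scatter). Compound 3 `COc1ccc(-c2nn(-c3ccccc3)cc2C(=O)/C=C\Nc2ccc(O)cc2)cc1` is built on a second core, and in this assay compound 3 gives 2770 nM, the step being a 1.5-fold higher number from compound 1 to compound 3 (0.16 log units; within the scatter). The two cores differ by methoxy in place of chloro on an aromatic carbon. Compound 4 `COc1ccc(N/C=C\C(=O)c2cn(-c3ccccc3)nc2-c2ccc(OC)cc2)cc1` is not yet measured; it differs from compound 3 by methyl in place of hydrogen on an oxygen on an aromatic ring, the same change that turns compound 1 into compound 2, and the place of the change is described in the same words in both pairs, so it is taken as the same change on a different core. Within the data shown here, the step in this assay is expected to be about a 3.4-fold higher number from compound 3 to compound 4 (0.53 log units; beyond the scatter), beside the earlier 3.4-fold higher number from compound 1 to compound 2 (0.53 log units; beyond the scatter), because the one measured instance of this change gave a 3.4-fold higher number from compound 1 to compound 2 (0.53 log units; beyond the scatter) and nothing speaks against carrying it over; only one such pair exists, so the range is kept wide. Compound 4 is accordingly estimated at 9400 nM, between 4500 nM and 20000 nM.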

Compound 4, half-maximal inhibitory concentration: 6780 nM
Beside the measured number, compound 4's estimate is 1.4-fold (0.14 log units) above it; low and high end bracket the measured number.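

In this assay hydroxy to methoxy on the second core gives a 2.4-fold higher number from compound 3 to compound 4 (0.39 log units; beyond the scatter) and so repeats the rise seen on the core of compound 1, with the two steps agreeing in size: the same change on two cores in this assay, a 3.4-fold higher number (0.53 log units; beyond the scatter) from compound 1 to compound 2 and a 2.4-fold higher number (0.39 log units; beyond the scatter) from compound 3 to compound 4, 1.4-fold (0.14 log units) apart, within the scatter of two such steps. The exchange of chloro for methoxy on the aromatic carbon, read on the methylated pair, gives a 1.0-fold higher number from compound 2 to compound 4 (0.02 log units; within the scatter) and likewise agrees with its earlier counterpart: the same change on two cores in this assay, a 1.5-fold higher number (0.16 log units; within the scatter) from compound 1 to compound 3 and a 1.0-fold higher number (0.02 log units; within the scatter) from compound 2 to compound 4, 1.4-fold (0.14 log units) apart, within the scatter of two such steps. Among these compounds, the four compounds therefore show that, in this assay, the two changes carry over between these two cores, but with only one pair per core this does not show that the step would hold on any further core, and it gives no reason for the rise.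

From the compounds shown here alone, whether a longer chain on the oxygen, such as ethoxy, or an amine in place of the hydroxy would follow the same step remains open. Also open, going by these compounds, is whether the step survives on a core bearing a group other than chloro or methoxy, such as a nitrile.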